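Series notes: benzoyl on the aminopropyl chain

A few compounds are considered here, and "the series" means these few. Any claim that something is new, unique, unknown or untested is made for them only; others in the source may bear on it.

Values in a functional assay on HCT-116 cells (Homo sapiens) for cytotoxicity, read by MTT assay, with a stated time of 72 h (a lower number here means a stronger inhibitor, a higher number a weaker inhibitor), so far:
compound 1 `NCCCNc1c(C(=O)NCc2ccc(F)cc2)nc(Br)c2cccnc12`: > 20000 nM
compound 2 `Nc1ccc(Nc2c(C(=O)NCc3ccc(F)cc3)nc(Br)c3cccnc23)cc1`: 10000 nM
compound 3 `N[C@H]1CC[C@H](Nc2c(C(=O)NCc3ccc(F)cc3)nc(Br)c3cccnc23)CC1`: 7000 nM

Compound 1 stands at the edge of this assay: its value is a limit, not a number, as the limit of > 20000 nM in this assay, at which 1 of the 3 values shown sits, shows. Both measured steps away from compound 1 replace the entire 3-aminopropyl chain and give lower numbers, an at least 2.0-fold lower number from compound 1 to compound 2 (0.30 log units; that floor lies within the scatter) and an at least 2.8-fold lower number from compound 1 to compound 3 (0.45 log units; beyond the scatter), while compound 2 and compound 3 stand within the scatter of each other, a 1.4-fold lower number from compound 2 to compound 3 (0.15 log units; within the scatter).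

Compound 4 `O=C(NCCCNc1c(C(=O)NCc2ccc(F)cc2)nc(Br)c2cccnc12)c1ccccc1` keeps the 3-aminopropyl chain and differs from compound 1 only by benzoyl in place of hydrogen on an amine nitrogen. Among the compounds with values here, no measured step touches this amine nitrogen while keeping the chain, so none bears directly on the change; the two steps that do exist only show that leaving the 3-aminopropyl chain in place has so far gone with the weakest value. The expectation for compound 4 is therefore a number near the limit, with a step of an at least 1.3-fold lower number from compound 1 to compound 4 (0.12 log units; that floor lies within the scatter) expected to be small. Compound 4 is estimated at 15000 nM, with a range from 5000 nM to 40000 nM.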

Compound 4, half-maximal inhibitory concentration: > 10000 nM
Compound 4: no number, only a limit; the forecaster's own chance of this, stated with the estimate: 45%; the middle value lies beyond the limit too.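

Compound 1 and compound 4 both carry only limits in this assay, and the step between them cannot be read. From the compounds shown here alone, what stays open is whether benzoyl in place of hydrogen on the amine nitrogen of the 3-aminopropyl chain changes the value in this assay at all.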